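The compounds below may be only part of what the source reports. "The series", "measured", "known", "first", "only" and "open" are said of these compounds alone.

Of the compounds shown here, three sharing one core have been measured so far. Compound 1 `Cc1ccc(NC(=O)COc2ccc3cc(/C=C4/SC(=O)NC4=O)ccc3c2)cc1` gives 1700 nM in an assay on isolated protein for inhibition of histone deacetylase 4 (Homo sapiens), with a stated time of 1 h; on this read-out lower numbers stand for stronger inhibition and higher numbers for weaker inhibition. Compound 2 `O=C(COc1ccc2cc(/C=C3/SC(=O)NC3=O)ccc2c1)Nc1ccc(Br)cc1F` gives 1900 nM in this assay, and compound 3 `O=C(COc1ccc2cc(/C=C3/SC(=O)NC3=O)ccc2c1)Nc1ccc(Cl)c(Cl)c1` gives 5500 nM in this assay. Among these three numbers compound 3 stands highest, which here means the weakest inhibition: the step of a 3.2-fold higher number from compound 1 to compound 3 (0.51 log units; beyond the scatter) and the step of a 2.9-fold higher number from compound 2 to compound 3 (0.46 log units; beyond the scatter) both go beyond the usual scatter, whereas the step of a 1.1-fold higher number from compound 1 to compound 2 (0.05 log units; within the scatter) does not.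

Compound 4 `Cc1ccc(NC(=O)COc2ccc3cc(/C=C4/SC(=O)NC4=O)ccc3c2)cc1Cl` differs from compound 3 in one place: methyl in place of chloro on an aromatic carbon. It therefore sits between compound 1, which carries the 4-methylphenyl group, and compound 3, which carries the 3,4-dichlorophenyl group. Within the data shown here, the only measured step that bears directly on this change is a 3.2-fold higher number from compound 1 to compound 3 (0.51 log units; beyond the scatter), where the methyl gave way to two chloro groups at once and the number rose modestly. Compound 4 puts the methyl back while keeping one chloro, so part of that step is expected to reverse, giving a modest move toward stronger inhibition. The step expected is a 2.0-fold lower number from compound 3 to compound 4 (0.29 log units; within the scatter). Compound 4 is estimated at 2800 nM in this assay, with a likely range from 1300 nM to 6000 nM.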

Compound 4, half-maximal inhibitory concentration: 1100 nM
The estimate for compound 4 lay 2.5-fold (0.41 log units) above the measured number, outside the stated range (below it).
By their numbers in this assay, from the lowest: compounds 4, 1 and 2 (each within the scatter of the next); then compound 3.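

In this assay, among these compounds, the single swap of chloro for methyl, at the place para to a large group and ortho to a chloro group, gives a step beyond the scatter: a 5.0-fold lower number from compound 3 to compound 4 (0.70 log units; beyond the scatter). The earlier step, a 3.2-fold higher number from compound 1 to compound 3 (0.51 log units; beyond the scatter), changed two ring places at once, whereas the new compound separates them: chloro in place of hydrogen gives a 1.5-fold lower number from compound 1 to compound 4 (0.19 log units; within the scatter), which is within the scatter, so among these compounds the rise in the earlier step goes with losing the methyl rather than with adding the second ring substituent. Among the compounds shown here, the step of a 1.7-fold lower number from compound 2 to compound 4 (0.24 log units; within the scatter) is also within the scatter, which leaves the 3,4-dichlorophenyl group of compound 3 as the only aryl group here that stands apart from the others, with weaker inhibition.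

Nothing available explains why methyl and chloro differ at this place. On these data alone, it also remains open whether the effect is particular to methyl or would extend to other groups at this place, such as ethyl, methoxy or an amine, and whether a hydrogen there, with the chloro kept, would match compound 3 or compound 4.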